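The compounds below may be only part of what the source reports. "The series", "measured", "known", "first", "only" and "open" are said of these compounds alone.

Of the compounds shown here, two have been tested so far. Compound 1 `COc1ccc2[nH]c(-c3cc(-c4cccc(F)c4)on3)cc2c1` gives only a limit of the assay, not a number: in a functional assay on COLO 320 cells (Homo sapiens) for cytotoxicity, read by WST assay, with a stated time of 72 h (on this read-out lower numbers stand for stronger inhibition and higher numbers for weaker inhibition), compound 1 gives > 100000 nM, which is the limit of > 100000 nM in this assay, at which 1 of the 2 values shown sits. For the measured compounds named here, compound 2 `O=[N+]([O-])c1ccc(-c2cc(-c3ccc4[nH]ccc4c3)on2)cc1` is the only compound with an actual number, and in this assay compound 2 gives 14000 nM. Compound 3 `Fc1ccc(-c2cc(-c3ccc4[nH]ccc4c3)on2)cc1` remains to be measured. It differs from compound 2 in one place, (fluoro in place of nitro on an aromatic carbon). Going by the values given here, no measured pair of this kind exists here, so the step of a 2.9-fold higher number from compound 2 to compound 3 (0.46 log units; beyond the scatter) is expected to run toward weaker inhibition, somewhat beyond the usual scatter. Compound 3 is therefore estimated at 40000 nM, with a likely range from 10000 nM to 150000 nM.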

Compound 3, half-maximal inhibitory concentration: 13900 nM
The estimate for compound 3 lay 2.9-fold (0.46 log units) above the measured number, within the range that was stated.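

In this assay the swap of nitro for fluoro, on an aromatic carbon para to a large group, gives a 1.0-fold lower number from compound 2 to compound 3 (0.00 log units; within the scatter). The two compounds cannot be told apart here, so at this position the nitro group, with its three heavy atoms, is not required for this level of activity: the single fluorine serves equally well. Nothing measured here explains this result. On these data alone, whether an amine or a carboxylic acid at the same position would give a different number stays open. So does the effect of moving fluoro to another carbon of that ring.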